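Quinoline amine macrolides: solubility at the assay limit

The source may report more compounds than this note shows. Statements on the series, on what has been measured and on what is new or still open speak of the compounds shown alone.

Measured so far:
- compound 1 `CC[C@H]1OC(=O)[C@H](C)[C@@H](O[C@H]2C[C@@](C)(OC)[C@@H](O)[C@H](C)O2)[C@H](C)[C@@H](O[C@@H]2O[C@H](C)C[C@H](N(C)C)[C@H]2OCCCNc2ccnc3cc(Cl)ccc23)[C@](C)(O)C[C@@H](C)CN(C)[C@H](C)[C@@H](O)[C@]1(C)O`: in a physicochemical assay for solubility, at pH 4 (a higher number here means a more soluble compound, a lower number a less soluble compound), compound 1 gives > 10000 ug/mL, a limit.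
- compound 2 `CC[C@H]1OC(=O)[C@H](C)[C@@H](O[C@H]2C[C@@](C)(OC)[C@@H](O)[C@H](C)O2)[C@H](C)[C@@H](O[C@@H]2O[C@H](C)C[C@H](N(C)C)[C@H]2OCCCNCc2cnc3ccccc3c2)[C@](C)(O)C[C@@H](C)CN(C)[C@H](C)[C@@H](O)[C@]1(C)O`: in this assay compound 2 gives > 10000 ug/mL, a limit.
- compound 3 `CC[C@H]1OC(=O)[C@H](C)[C@@H](O[C@H]2C[C@@](C)(OC)[C@@H](O)[C@H](C)O2)[C@H](C)[C@@H](O[C@@H]2O[C@H](C)C[C@H](N(C)C)[C@H]2OCCCNCc2ccc3ccccc3n2)[C@](C)(O)C[C@@H](C)CN(C)[C@H](C)[C@@H](O)[C@]1(C)O`: in this assay compound 3 gives > 10000 ug/mL, a limit.

Compound 2 therefore stands only at a limit, not at a number, as do the other two: the limit of > 10000 ug/mL in this assay, at which 3 of the 3 values shown sit. The measured steps a step that the two limits leave unreadable from compound 1 to compound 2, a step that the two limits leave unreadable from compound 1 to compound 3 and a step that the two limits leave unreadable from compound 2 to compound 3 all change the group on the amine nitrogen and all stay unreadable.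

Compound 4 `CC[C@H]1OC(=O)[C@H](C)[C@@H](O[C@H]2C[C@@](C)(OC)[C@@H](O)[C@H](C)O2)[C@H](C)[C@@H](O[C@@H]2O[C@H](C)C[C@H](N(C)C)[C@H]2OCCCN(C)Cc2cnc3ccccc3c2)[C@](C)(O)C[C@@H](C)CN(C)[C@H](C)[C@@H](O)[C@]1(C)O` differs from compound 2 by methyl in place of hydrogen on an amine nitrogen. Going by the values given here, no measured step puts a methyl on that nitrogen; the neighbouring steps show nothing readable. Compound 4 is expected to remain at the limit, with the step of a number no higher from compound 2 to compound 4 (the limit leaves the size open) expected to be unreadable. The estimate for compound 4 is 10000 ug/mL, range 5000 ug/mL to 10000 ug/mL.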

Compound 4, solubility: > 10000 ug/mL
Compound 4: a limit, no number; the forecaster's own chance of this, stated with the estimate: 85%; the middle value lies on the limit itself.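

Compound 4 gives > 10000 ug/mL in this assay, a limit, so its step from compound 2 cannot be read. The compounds shown leave open whether the group on the amine nitrogen changes the read-out at all: the limit of > 10000 ug/mL in this assay, at which 4 of the 4 values shown sit.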